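This account rests on a few compounds, and the source may have more. Where it says the series, first, only, none or still open, it means among the compounds named here.

Of the compounds shown here, three built on one shared core have been measured in a functional assay on A549 cells (Homo sapiens) for cytotoxicity, read by MTT assay, with a stated time of 48 h; on this read-out higher numbers stand for weaker inhibition and lower numbers for stronger inhibition. Compound 1 `CCOC(=O)[C@]1(C(=O)NCc2ccc(C)cc2)C[C@H]1c1cc(OC)c(OC)c(OC)c1` gives 13300 nM. Compound 2 `COc1cc([C@@H]2C[C@]2(CO)C(=O)NCc2ccc(C)cc2)cc(OC)c1OC` gives 10500 nM. Compound 3 `COc1cc([C@@H]2C[C@]2(CO)C(=O)Nc2ccccc2)cc(OC)c1OC` gives 24100 nM. Compound 2 is the reference point here: the move a 1.3-fold lower number from compound 1 to compound 2 (0.10 log units; within the scatter) leaves compound 1 and compound 2 indistinguishable, whereas the move a 2.3-fold higher number from compound 2 to compound 3 (0.36 log units; beyond the scatter) separates compound 3 from compound 2 in this assay.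

Compound 4 `COc1cc([C@@H]2C[C@@]2(CO)C(=O)NCc2ccc(C)cc2)cc(OC)c1OC` is the next compound to be tested in this assay. How it differs from compound 2 is the two compounds have the same atoms and bonds and differ only in configuration as drawn: 1 of 2 stereo elements differ; a stereocentre at a saturated ring carbon is drawn S in compound 2 and R in compound 4

Neither measured step bears directly on this kind of change. The step from compound 1 to compound 2 swapped one group for another on the ring, and the step from compound 2 to compound 3 swapped the group on the amide nitrogen; both kept the drawn configuration fixed. Going by the values given here, no measured pair here differs only in configuration, so there is nothing to anchor the direction of the change. Changes of configuration alone can leave the number unchanged or shift it noticeably in either sense, so the expected step of a 1.4-fold higher number from compound 2 to compound 4 (0.15 log units; within the scatter) is set near zero with a wide spread. Compound 4 is therefore expected to give about 15000 nM, with a likely range from 6000 nM to 45000 nM.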

Compound 4, half-maximal inhibitory concentration: 46300 nM
The estimate for compound 4 lay 3.1-fold (0.49 log units) below the measured number; the whole stated range lies below it.
By their numbers in this assay, from the lowest: compounds 2, 1, 3 and 4 (each within the scatter of the next, the first and the last beyond it).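

In this assay, the drawn configuration at a saturated ring carbon proves to matter: changing it from S to R gives a 4.4-fold higher number from compound 2 to compound 4 (0.64 log units; beyond the scatter). The earlier steps shown here changed groups while the configuration stayed fixed, and one of them, swapping ethoxycarbonyl for hydroxymethyl on a saturated ring carbon, gave a 1.3-fold lower number from compound 1 to compound 2 (0.10 log units; within the scatter), so the compounds before this one could say nothing about the spatial arrangement. Here the shift can be assigned to configuration alone, because no atom or bond changes, which makes this pair a clean comparison: the fact that compounds 2 and 4 differ only in the configuration as drawn.

Still open, as far as these compounds go, is whether the same change of configuration would have a similar effect with ethoxycarbonyl in place of hydroxymethyl, or with phenyl in place of 4-methylbenzyl on the amide nitrogen, and what changing the second stereo element would do. Also open, from the compounds shown here alone, is how a carboxylic acid or an amine in place of hydroxymethyl would behave in either configuration.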